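From 4-fluorophenyl to 4-methylphenyl on the sulfonyl group

This account rests on a few compounds, and the source may have more. Where it says the series, first, only, none or still open, it means among the compounds named here.

In a functional assay on LOX IMVI cells (Homo sapiens) for cytotoxicity, read by MTT assay, with a stated time of 24 h (on this read-out higher numbers stand for weaker inhibition and lower numbers for stronger inhibition), compound 3 `O=S(=O)(NCCCNc1nccc(-c2[nH]c(-c3ccccc3)nc2-c2ccc(F)c(O)c2)n1)c1ccc(F)cc1` gives 19200 nM, within the scatter of compound 2 `O=S(=O)(NCCCNc1nccc(-c2[nH]c(-c3ccccc3)nc2-c2ccc(F)c(O)c2)n1)c1ccccc1` at 9580 nM. Compound 1 `COc1cc(-c2nc(-c3ccccc3)[nH]c2-c2ccnc(NCCCNS(=O)(=O)c3ccc(C)cc3)n2)ccc1F` gives 2590 nM, a lower number than compound 3, beyond the scatter.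

Compound 4 `Cc1ccc(S(=O)(=O)NCCCNc2nccc(-c3[nH]c(-c4ccccc4)nc3-c3ccc(F)c(O)c3)n2)cc1` differs from compound 3 by methyl in place of fluoro on an aromatic carbon. Among the measured compounds shown here, the only measured step at this position is a 2.0-fold higher number from compound 2 to compound 3 (0.30 log units; within the scatter), with fluoro in place of hydrogen. Compound 1 also carries 4-methylphenyl but differs from compound 4 elsewhere, so compound 1 at 2590 nM is only a weak pointer towards a lower number.

The expected change, a small one, is a 1.9-fold lower number from compound 3 to compound 4 (0.28 log units; within the scatter). For compound 4 the estimated value is 10000 nM, with an expected range of 4000 nM to 25000 nM.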

Compound 4, half-maximal inhibitory concentration: 26300 nM
Compound 4: the middle estimate sits 2.6-fold (0.42 log units) below what was measured; measured number above the stated range.
By their numbers in this assay, from the lowest: compound 1; then compounds 2, 3 and 4 (each within the scatter of the next, the first and the last beyond it).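

In this assay there is a 1.4-fold higher number from compound 3 to compound 4 (0.14 log units; within the scatter) and so methyl and fluoro are not separated at this position, whereas there is a 2.7-fold higher number from compound 2 to compound 4 (0.44 log units; beyond the scatter) and so methyl is separated from hydrogen. With 4-methylphenyl held constant, there is a 10-fold higher number from compound 1 to compound 4 (1.01 log units; beyond the scatter) and this step on the oxygen exceeds every step seen at the 4-position of the sulfonyl phenyl ring. No measurement here accounts for these steps. From the compounds shown here alone, whether an amine or a carboxylic acid at this position would shift the number remains open. So does whether the methyl on the oxygen gives a similar step with 4-fluorophenyl on the sulfonyl group.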